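The compounds below may be only part of what the source reports. "The series", "measured", "known", "first", "only" and "open" are said of these compounds alone.

In a functional assay on CCRF-CEM cells (Homo sapiens) (on this read-out lower numbers stand for stronger inhibition and higher numbers for weaker inhibition), compound 1 `Cc1ccc(/C=C/C(=O)Oc2ccc(/C=C3\CCCCC3=O)cc2)cc1` gives 230000 nM and compound 2 `O=C(/C=C/c1ccc(F)cc1)Oc1ccc(/C=C2\CCCCC2=O)cc1` gives 14400 nM, while compound 3 `CN(C)CC1CCC/C(=C\c2ccc(OC(=O)/C=C/c3ccc(F)cc3)cc2)C1=O` gives 6000 nM as the lowest number of the three. The step to compound 4 `COc1ccc(C(=O)Oc2ccc(/C=C3\CCCC(CN(C)C)C3=O)cc2)cc1` is 4-methoxyphenyl in place of 2-(4-fluorophenyl)ethenyl on a carbonyl carbon and amounts to 4-methoxyphenyl in place of 2-(4-fluorophenyl)ethenyl on a carbonyl carbon. The large step of a 16-fold lower number from compound 1 to compound 2 (1.20 log units; beyond the scatter) came with fluoro in place of methyl on an aromatic carbon, and compound 4 has no fluoro. The modest step of a 2.4-fold lower number from compound 2 to compound 3 (0.38 log units; beyond the scatter) came with (dimethylamino)methyl in place of hydrogen on a saturated ring carbon, and compound 4 keeps that group. Among the measured compounds shown here, no measured step replaces the whole 2-(4-fluorophenyl)ethenyl group, so the evidence is indirect. A modest rise in this assay is therefore expected, with the estimated change being a 1.7-fold higher number from compound 3 to compound 4 (0.22 log units; within the scatter) toward weaker inhibition. For compound 4 the estimated value is 10000 nM with an expected range from 2500 nM to 40000 nM on this reasoning.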

Compound 4, half-maximal inhibitory concentration: 5070 nM
Compound 4: the middle estimate sits 2.0-fold (0.29 log units) above what was measured, and the stated range covers the measured number.
By their numbers in this assay, from the lowest: compounds 4 and 3 (each within the scatter of the next); then compound 2; then compound 1.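

In this assay, the whole group on the carbonyl carbon was exchanged, 4-methoxyphenyl for 2-(4-fluorophenyl)ethenyl, and the result was a 1.2-fold lower number from compound 3 to compound 4 (0.07 log units; within the scatter). The earlier compounds shown here showed only a change on the aromatic ring of that group, a 16-fold lower number from compound 1 to compound 2 (1.20 log units; beyond the scatter), whereas here the double bond outside aromatic rings leaves along with the fluorine and the number stays within the scatter. Nothing measured here explains this result. The compounds shown leave open whether 4-methoxyphenyl would give a similar number without the (dimethylamino)methyl group. They also leave open how an amine or a carboxylic acid in place of the methoxy group would read.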